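A few compounds are considered here, and "the series" means these few. Any claim that something is new, unique, unknown or untested is made for them only; others in the source may bear on it.

The series opens with three close analogues of one shared core, each carrying a differently substituted phenyl ring on an aromatic nitrogen. In a functional assay on HCT-116 cells (Homo sapiens) for antiproliferative activity, read by MTT assay, with a stated time of 48 h (a higher number here means a weaker inhibitor, a lower number a stronger inhibitor), compound 1 `Cc1ccccc1-n1nncc1CN1C(=O)C2(C(C#N)=C(N)Oc3c2c2nc4ccccc4nc2c2ccccc32)c2ccccc21` gives > 50000 nM, which is a limit of the assay and not a number. Compound 2 `N#CC1=C(N)Oc2c(c3nc4ccccc4nc3c3ccccc23)C12C(=O)N(Cc1cnnn1-c1ccc(Cl)cc1)c1ccccc12` likewise gives > 50000 nM, again only a limit. Compound 3 `CCc1cccc(C)c1-n1nncc1CN1C(=O)C2(C(C#N)=C(N)Oc3c(N)cc4nc5ccccc5nc4c32)c2ccccc21` gives > 50000 nM, a limit as well. Where compound 3 stands is therefore known only as a bound: all three values sit at the limit of > 50000 nM in this assay, at which 3 of the 3 values shown sit, and the single one-place step available, a step that the two limits leave unreadable from compound 1 to compound 2, cannot be read in size or direction because both of its ends are limits.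

Compound 4 `Cc1cc(C)c(-n2nncc2CN2C(=O)C3(C(C#N)=C(N)Oc4c(N)cc5nc6ccccc6nc5c43)c3ccccc32)c(C)c1` differs from compound 3 by 2,4,6-trimethylphenyl in place of 2-ethyl-6-methylphenyl on an aromatic nitrogen. Going by the values given here, no measured step bears on this change with a readable size, and none of the measured compounds has given a number in this assay. The expectation for compound 4 can therefore only be that it stays where the others stand. The step of a number no higher from compound 3 to compound 4 (the limit leaves the size open) is estimated to be no change beyond the scatter, with the assay most likely reporting a limit again. Compound 4 is accordingly expected to give about 50000 nM, within a range of 20000 nM to 100000 nM.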

Compound 4, half-maximal inhibitory concentration: > 50000 nM
Compound 4 ended at the assay's limit; the forecaster's own chance of this, stated with the estimate: 85%; the middle value lies on the limit itself.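

In this assay compound 4 gives > 50000 nM, which is a limit and not a number. The change from compound 3 to compound 4 therefore cannot be read in size or direction. The compounds shown leave open which structure, if any, would give a measurable value, since all of them stand at one bound: the limit of > 50000 nM in this assay, at which 4 of the 4 values shown sit.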